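Methylating a Phenol: One Step Measured, One Step Foreseen

The source may report more compounds than this note shows. Statements on the series, on what has been measured and on what is new or still open speak of the compounds shown alone.

Compound 1 `O=C(Nc1cccc(-n2cc(-c3ccncc3)c(-c3cc(O)cc(Cl)c3)n2)c1)Nc1ccc(Cl)c(Cl)c1` gives -5.53% in a functional assay on T47D cells (Homo sapiens) for inhibition, read by sulforhodamine B assay, with a stated time of 48 h, tested at 10 uM; a higher number here means a weaker effect of the compound at the concentration tested, a lower number a stronger effect.
Compound 2 `COc1cc(Cl)cc(-c2nn(-c3cccc(NC(=O)Nc4ccc(Cl)c(Cl)c4)c3)cc2-c2ccncc2)c1` gives 18.6% in this assay.
Compound 3 `O=C(Nc1cccc(-n2cc(-c3ccncc3)c(-c3cc(O)cc(Cl)c3)n2)c1)c1cc(C(F)(F)F)cc(C(F)(F)F)c1` gives 26.3% in this assay.

Of the compounds shown here, three have been measured and a fourth awaits its number. Compound 1 and compound 2 share one core and differ in a single place: methyl in place of hydrogen on an oxygen on an aromatic ring. That change made a step of a number 24.1 percentage points higher from compound 1 to compound 2 (beyond the scatter), so the methylated compound 2 is the weaker of the pair at the concentration tested. Compound 3 carries the same hydroxy group as compound 1 but a different core; the difference between the two cores is not broken down here. Its value and that of compound 2 lie within the usual scatter of each other, while its gap to compound 1 lies beyond it.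

Compound 4 `COc1cc(Cl)cc(-c2nn(-c3cccc(NC(=O)c4cc(C(F)(F)F)cc(C(F)(F)F)c4)c3)cc2-c2ccncc2)c1` is the methylated counterpart of compound 3: methyl in place of hydrogen on an oxygen on an aromatic ring. The place is described in the same words for both pairs, so this is the same change, made here on the second core. For the measured compounds named here, because a number 24.1 percentage points higher from compound 1 to compound 2 (beyond the scatter) is the only measured instance of this change, the same direction is expected on the second core, with a step estimated at a number 13.7 percentage points higher from compound 3 to compound 4 (beyond the scatter). Compound 3 already gives a number well away from that of compound 1, and one example on another core gives little certainty about size, so the expected range is wide. Compound 4 is therefore estimated at 40% in this assay, with a range from 15% to 65%.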

Compound 4, a percentage reported as activity, at one concentration (the size of the read-out at that concentration, not a potency): 53.4%
Beside the measured number, compound 4's estimate is 13.4 percentage points below it; the range from low to high includes it.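

On the second core, the change from hydroxy to methoxy gave a number 27.1 percentage points higher from compound 3 to compound 4 (beyond the scatter), so here too the methylated partner shows the weaker effect at the concentration tested in this assay. The two steps point the same way and cannot be told apart in size, which means that in these two pairs the change carried over from one core to the other with its direction and its approximate size intact: the same change on two cores in this assay, a number 24.1 percentage points higher (beyond the scatter) from compound 1 to compound 2 and a number 27.1 percentage points higher (beyond the scatter) from compound 3 to compound 4, 3 percentage points apart, within the scatter of two such steps This shows that the step from the first core was a fair guide to the step on the second, but two pairs cannot establish a rule for other cores in the series, and a read-out at one concentration is not a potency and does not explain why the step arises.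

The compounds shown carry only hydroxy or methoxy on this ring, so it remains open how an amine or a longer ether such as ethoxy would read at the same place in this assay. Also open, as far as these compounds go, is whether the step keeps its direction and size on a core other than these two.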